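Anilino-Butenolide Steroid Analogues: Cytotoxicity on KB Cells

A few compounds are considered here, and "the series" means these few. Any claim that something is new, unique, unknown or untested is made for them only; others in the source may bear on it.

The account concerns two measured compounds and one that has not yet been tested. Compound 1, with the structure `C=C1[C@@H](OC(C)=O)C[C@@H]2[C@](C)(CO[Si](C)(C)C(C)(C)C)[C@H](OC(C)=O)CC[C@@]2(C)[C@@H]1C[C@@H](Nc1ccccc1F)C1=CCOC1=O`, carries a 2-fluorophenyl group on an amine nitrogen next to a butenolide ring; in a functional assay on KB cells (Homo sapiens) for cytotoxicity, read by sulforhodamine B assay (on this read-out lower numbers stand for stronger inhibition and higher numbers for weaker inhibition), compound 1 gives 4740 nM. Going by the values given here, compound 2, with the structure `C=C1[C@@H](OC(C)=O)C[C@@H]2[C@](C)(COC=O)[C@H](OC(C)=O)CC[C@@]2(C)[C@@H]1C[C@@H](Nc1ccccc1)C1=CCOC1=O`, is the only other compound measured, and in this assay compound 2 gives 32100 nM. Among the compounds with values here, compound 1 therefore stands at the lowest of the two numbers, and its gap to compound 2 lies beyond the usual scatter; since the two compounds differ in more than one place, no single step between them can be drawn.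

Compound 3, with the structure `C=C1[C@@H](OC(C)=O)C[C@@H]2[C@](C)(CO[Si](C)(C)C(C)(C)C)[C@H](OC(C)=O)CC[C@@]2(C)[C@@H]1C[C@@H](Nc1ccc(OC)c(OC)c1)C1=CCOC1=O`, differs from compound 1 in one place: 3,4-dimethoxyphenyl in place of 2-fluorophenyl on an amine nitrogen. Within the data shown here, no measured pair shows this change, so the size of the step is unknown; the expectation is a step in this assay that may be small, perhaps none beyond the scatter, or a mild weakening. On that basis compound 3 is estimated at 7000 nM, within a range from 1800 nM to 28000 nM, which corresponds to an expected step of a 1.5-fold higher number from compound 1 to compound 3 (0.17 log units; within the scatter).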

Compound 3, half-maximal inhibitory concentration: 5800 nM
Estimate against measurement, compound 3: 1.2-fold (0.08 log units) above, and the stated range covers the measured number.
By their numbers in this assay, from the lowest: compounds 1 and 3 (each within the scatter of the next); then compound 2.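

In this assay, replacing 2-fluorophenyl with 3,4-dimethoxyphenyl on an amine nitrogen whose other neighbour is a saturated chain carbon gives a 1.2-fold higher number from compound 1 to compound 3 (0.09 log units; within the scatter), so this assay does not separate the two groups at this position. The entering group has more heavy atoms and two hydrogen-bond acceptors where the leaving group has none, yet this larger substituted phenyl leaves the reading within the scatter, at least for this one pair on the core of compound 1. Nothing measured here accounts for why the two groups read alike.

The compounds shown leave open whether a group of another kind on this nitrogen, such as a benzyl group or a pyridine ring, would read differently, and whether an unsubstituted phenyl or a single methoxy group would read like these two with the rest of compound 1 kept in place. From the compounds shown here alone, compound 2 differs from compound 1 and from compound 3 in more than one place, so the steps to it cannot be read, and the part played by the silyl ether as against the formate ester stays open.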